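Piperazin-1-yl Replaces 4-(Piperidin-1-yl)piperidin-1-yl on the Amide

The source may hold more compounds than are shown below. What is called first, only, known or untested is meant among the compounds shown, and "the series" means these compounds.

Of the compounds shown here, two have been measured in an assay on Sf21 cells for inhibition of MAP kinase-interacting serine/threonine-protein kinase 1 (Homo sapiens), read by luminescence and ADP-Glo, with stated times of 10 min and 40 min, tested at 500 nM; on this read-out higher numbers stand for more inhibition at the one concentration tested (going by the name of the read-out) and lower numbers for less inhibition. Compound 1 `O=C(c1ccc(-c2ccc3ncc(-c4ccc5ncccc5c4)n3c2)cc1)N1CCNCC1` gives 73.5% in this assay. Compound 2 `O=C(c1ccc(-c2ccc3ncc(-c4cnc5ccccc5c4)n3c2)cc1)N1CCC(N2CCCCC2)CC1` gives 71% in this assay. Compound 2 stands lowest of the two numbers, but its nearest neighbour is compound 1, and the two values fall within the scatter of each other. Among the compounds with values here, compound 1 and compound 2 differ in more than one place, so no single step links them; their two values show only that both amides reach a similar level of inhibition at this concentration.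

Compound 3 `O=C(c1ccc(-c2ccc3ncc(-c4cnc5ccccc5c4)n3c2)cc1)N1CCNCC1` has not yet been measured. It differs from compound 2 in one place: piperazin-1-yl in place of 4-(piperidin-1-yl)piperidin-1-yl on a carbonyl carbon. Compound 1 already carries piperazin-1-yl on its carbonyl carbon and gives 73.5% in this assay, so nothing seen so far suggests that the inhibition in this assay with this amide is lower than with the larger one. Compound 3 is therefore expected to give 72% in this assay, with a range from 55% to 85%. The expected step of a number 1 percentage points higher from compound 2 to compound 3 (within the scatter) is none beyond the scatter.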

Compound 3, a percentage reported as inhibition, at one concentration (the size of the read-out at that concentration, not a potency): 70.7%
Compound 3: middle estimate off by 1.3 percentage points, on the high side; low and high end bracket the measured number.
By their numbers in this assay, from the lowest: compounds 3, 2 and 1 (each within the scatter of the next).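

In this assay, the amide can now be read on its own, and the step is a number 0.3 percentage points lower from compound 2 to compound 3 (within the scatter): with piperazin-1-yl in place of 4-(piperidin-1-yl)piperidin-1-yl on the carbonyl carbon, 12 heavy atoms leave and 6 enter, yet the two amides cannot be told apart at the one concentration tested. The other new comparison holds the piperazin-1-yl amide fixed and puts quinolin-3-yl in place of quinolin-6-yl on an aromatic carbon, and it reads a number 2.8 percentage points lower from compound 1 to compound 3 (within the scatter), so these two quinoline attachments cannot be told apart in this read-out either. No other data on these compounds bear on why their values lie so close.

From the compounds shown here alone, what a morpholin-4-yl group, a dimethylamino group or a carboxylic acid would give on the same carbonyl carbon remains open. Going by these compounds, the read-out is also a percentage at a single concentration and not a potency, so whether these three compounds would still match across a range of concentrations remains open too.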